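Methylation of the sulfonamide nitrogen in the sulfamoyl series

The source may hold more compounds than are shown below. What is called first, only, known or untested is meant among the compounds shown, and "the series" means these compounds.

The series shares one core, varied only at the sulfonamide end. Compound 1 `CCN1CCCC1CNC(=O)c1cc(NS(=O)(=O)N(C)C)c(C)cc1OC` carries two methyls on the terminal sulfonamide nitrogen and in a functional assay on the whole organism for inhibition, with Mus musculus as the target (a higher number here means that more compound is needed for the effect, a lower number that less compound is needed), gives 13.3 mg/kg. Compound 2 `CCN1CCCC1CNC(=O)c1cc(NS(=O)(=O)NC)c(C)cc1OC` has one methyl there; in this assay compound 2 reaches only the limit > 50 mg/kg. Compound 3 `CCN1CCCC1CNC(=O)c1cc(NS(N)(=O)=O)c(C)cc1OC` has no methyl on that nitrogen; in this assay compound 3 likewise sits at the limit > 50 mg/kg, so its position on the numbers shown is an upper bound rather than a value, and it shares this with one of the other two compounds (the limit of > 50 mg/kg in this assay, at which 2 of the 3 values shown sit).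

The measured steps are an at least 3.7-fold higher number from compound 1 to compound 2 (0.57 log units; beyond the scatter) and an at least 3.7-fold higher number from compound 1 to compound 3 (0.57 log units; beyond the scatter), while a step that the two limits leave unreadable from compound 2 to compound 3 cannot be sized. Both readable steps point the same way: losing methyl from the terminal nitrogen raises the dose.

Compound 4 `CCN1CCCC1CNC(=O)c1cc(N(C)S(N)(=O)=O)c(C)cc1OC` differs from compound 3 by methyl in place of hydrogen on a sulfonamide nitrogen. The methyl enters on the nitrogen bonded to the aromatic carbon, not the terminal one the measured steps concern, so they bear on it only by analogy. A modest fall in dose is expected, an at least 1.2-fold lower number from compound 3 to compound 4 (0.09 log units; that floor lies within the scatter), though a limit remains likely. Compound 4 is estimated at 40 mg/kg, within 12 mg/kg to 150 mg/kg.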

Compound 4, dose for half-maximal effect: > 50 mg/kg
Compound 4 ended at the assay's limit; the forecaster's own chance of this, stated with the estimate: 55%; middle value at least 1.2-fold (0.09 log units) away from the limit.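

Placing methyl on the sulfonamide nitrogen bonded to the aromatic carbon gives no readable gain over hydrogen: in this assay compound 4 gives > 50 mg/kg, which is a limit of the assay and not a number. Against the compound with two methyls on the terminal nitrogen, the change gives an at least 3.7-fold higher number from compound 1 to compound 4 (0.57 log units; beyond the scatter), so a single methyl on the nitrogen bonded to the aromatic carbon does not match the dimethylamino end of the series. The steps to compound 4 from compound 2 and from compound 3 cannot be read, and compound 1 remains the only compound shown with a value off the limit: the limit of > 50 mg/kg in this assay, at which 3 of the 4 values shown sit.

The compounds shown leave open whether methyl on the nitrogen bonded to the aromatic carbon has any effect on the dose, since no pair differing only in that methyl gives a value on both sides. They also leave open how that methyl behaves alongside a terminal dimethylamino group, and whether a terminal diethylamino group would hold or lower the dose of compound 1.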